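Three sulfonate-bridged nucleosides and an untested propanamide analogue

The compounds below may be only part of what the source reports. "The series", "measured", "known", "first", "only" and "open" are said of these compounds alone.

Compound 1 `CC(=O)NC1=CS(=O)(=O)O[C@@]12[C@@H](CO[Si](C)(C)C(C)(C)C)O[C@@H](n1cc(C)c(=O)n(C)c1=O)[C@@H]2O[Si](C)(C)C(C)(C)C` gives 10700 nM in a functional assay on MT4 cells (Homo sapiens); on this read-out higher numbers stand for lower toxicity in this test and lower numbers for higher toxicity in this test.
Compound 2 `CCOC(=O)CNC(=O)NC1=CS(=O)(=O)O[C@@]12[C@@H](CO[Si](C)(C)C(C)(C)C)O[C@@H](n1cc(C)c(=O)n(C)c1=O)[C@@H]2O[Si](C)(C)C(C)(C)C` gives 3780 nM in this assay.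
Compound 3 `Cc1cn([C@@H]2O[C@H](CO[Si](C)(C)C(C)(C)C)[C@@]3(OS(=O)(=O)C=C3NCC(=O)C(=O)O)[C@H]2O[Si](C)(C)C(C)(C)C)c(=O)n(C)c1=O` gives 31100 nM in this assay.

Compound 2 stands lowest of the three numbers in this assay; compound 1 lies nearest, as a 2.8-fold lower number from compound 1 to compound 2 (0.45 log units; beyond the scatter) shows, and compound 3 furthest, as an 8.2-fold higher number from compound 2 to compound 3 (0.92 log units; beyond the scatter) shows. Compound 4 `Cc1cn([C@@H]2O[C@H](CO[Si](C)(C)C(C)(C)C)[C@@]3(OS(=O)(=O)C=C3NCCC(N)=O)[C@H]2O[Si](C)(C)C(C)(C)C)c(=O)n(C)c1=O` differs from compound 2 by 2-carbamoylethyl in place of ((ethoxycarbonyl)methyl)carbamoyl on an amine nitrogen. Both measured steps away from compound 2 run toward higher numbers: a 2.8-fold lower number from compound 1 to compound 2 (0.45 log units; beyond the scatter) read in reverse, and an 8.2-fold higher number from compound 2 to compound 3 (0.92 log units; beyond the scatter). A modest rise beyond the scatter is therefore expected for compound 4 in this assay. Compound 4 is estimated to give about 12000 nM, most likely between 4500 nM and 32000 nM. This estimate means a 3.2-fold higher number from compound 2 to compound 4 (0.50 log units; beyond the scatter).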

Compound 4, half-maximal cytotoxic concentration: 20000 nM
Compound 4: middle estimate off by 1.7-fold (0.22 log units), on the low side; measured number inside the range.
By their numbers in this assay, from the lowest: compound 2; then compounds 1, 4 and 3 (each within the scatter of the next, the first and the last beyond it).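

In this assay, 2-carbamoylethyl in place of ((ethoxycarbonyl)methyl)carbamoyl on the amine nitrogen gives a step beyond the scatter (a 5.3-fold higher number from compound 2 to compound 4 (0.72 log units; beyond the scatter)), so compound 2 stays apart from all three other compounds. Compound 4 falls within the scatter of both compound 3 (a 1.6-fold lower number from compound 3 to compound 4 (0.19 log units; within the scatter)) and compound 1 (a 1.9-fold higher number from compound 1 to compound 4 (0.27 log units; within the scatter)), although those two differ from each other beyond it. No evidence is available to explain these differences. The compounds shown leave open how an amine or a longer chain at this nitrogen would read.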